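A few compounds are considered here, and "the series" means these few. Any claim that something is new, unique, unknown or untested is made for them only; others in the source may bear on it.

Series notes. Compound 1 `C=CC(=O)Nc1cccc(Nc2nc(N/N=C/c3ccc(F)cc3)ncc2Cl)c1`, compound 2 `C=CC(=O)Nc1cccc(Nc2nc(N/N=C(\C)c3ccc(F)cc3)ncc2Cl)c1` and compound 3 `CN(C)C/C=C/C(=O)Nc1cccc(Nc2nc(N/N=C/c3ccccc3F)ncc2Cl)c1` share one core and have each been run in an ADME assay on HT-29 cells (Homo sapiens) for inhibition, read by MTT assay, with a stated time of 72 h; on this read-out lower numbers stand for stronger inhibition and higher numbers for weaker inhibition. Compound 1 gives 6340 nM, compound 2 gives 5050 nM and compound 3 gives 3660 nM. Among the measured compounds shown here, the one single-point step measured so far is a 1.3-fold lower number from compound 1 to compound 2 (0.10 log units; within the scatter). Compound 3 carries the lowest of the three numbers, yet its gaps to compound 2 and to compound 1 both sit inside the scatter, so the three compounds are not separated by these data.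

Compound 4 `C/C(=N\Nc1ncc(Cl)c(Nc2cccc(NC(=O)/C=C/CN(C)C)c2)n1)c1cccnc1` has not yet been run in this assay. It differs from compound 3 in one place: a group of 9 heavy atoms (7 carbon, 2 nitrogen; one six-membered aromatic ring with 1 hetero atom) in place of a group of 9 heavy atoms (7 carbon, 1 nitrogen, 1 fluorine; one six-membered aromatic ring of carbon only), on a nitrogen on an aromatic ring. For the measured compounds named here, the step from compound 1 to compound 2 is the only measured change at this same nitrogen, and it did not move the number beyond the scatter; no measured step exchanges the six-membered aromatic ring of carbon only for a six-membered aromatic ring with 1 hetero atom, so that part of the change has no precedent. The expectation for compound 4 is therefore a step of a 1.0-fold higher number from compound 3 to compound 4 (0.00 log units; within the scatter), meaning no change beyond the scatter. The estimate for compound 4 is 3700 nM, with a range from 1500 nM to 9000 nM.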

Compound 4, half-maximal inhibitory concentration: 9660 nM
Compound 4: the middle estimate sits 2.6-fold (0.42 log units) below what was measured, and the stated range ends below it.
By their numbers in this assay, from the lowest: compounds 3, 2, 1 and 4 (each within the scatter of the next, the first and the last beyond it).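

In this assay, among the compounds shown here, the exchange on this nitrogen on an aromatic ring gives the first step that lies beyond the scatter (a 2.6-fold higher number from compound 3 to compound 4 (0.42 log units; beyond the scatter)), so this position does respond to its substituent, though the step is modest and points towards weaker inhibition. The earlier step at the same nitrogen (a 1.3-fold lower number from compound 1 to compound 2 (0.10 log units; within the scatter)) kept the six-membered aromatic ring of carbon only and its fluorine on both sides and stayed within the scatter, whereas here the ring gains a hetero atom, the fluorine is gone and a methyl group enters, all in one step. No measurement at hand bears on why the number rises.

The compounds shown do not separate the contributions of the ring exchange, the loss of fluorine and the added methyl group, and the methyl group has been read only alongside a different amide side chain from the one in compound 3 and compound 4. An unsubstituted phenyl group, or a six-membered aromatic ring of carbon only bearing an amine or a methoxy group, would be needed at this nitrogen to show how far the step belongs to the ring hetero atom.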